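Swapping nitro for amino where both neighbours hit the limit

This account rests on a few compounds, and the source may have more. Where it says the series, first, only, none or still open, it means among the compounds named here.

Compound 1 `COc1ccc(/C=C/c2ccc3ccccc3c2)cc1`: > 5000 nM (a limit)
Compound 2 `COc1ccc(/C=C/c2ccc3ccccc3c2)cc1[N+](=O)[O-]`: > 5000 nM (a limit)

The measurements come from a functional assay on A549 cells (Homo sapiens) for inhibition; on this read-out lower numbers stand for stronger inhibition and higher numbers for weaker inhibition. There, compound 2 gives > 5000 nM, which is a limit and not a number. The same is true of compound 1, which gives > 5000 nM, so neither compound has an exact value.

The next structure is compound 3 `COc1ccc(/C=C/c2ccc3ccccc3c2)cc1N`, and the change is amino in place of nitro on an aromatic carbon. Among the compounds with values here, only one measured step bears on it, a step that the two limits leave unreadable from compound 1 to compound 2, which puts nitro in place of hydrogen on an aromatic carbon. That step offers no size to carry over, and it says nothing directly about an amino group. The evidence amounts to the limit of > 5000 nM in this assay, at which 2 of the 2 values shown sit. Compound 3 is therefore expected to remain a weak inhibitor, with no clear step in either direction and a good chance of reaching the limit again.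

For compound 3 the estimated value is 6000 nM, with an expected range from 1500 nM to 20000 nM. The expected change is a step that the limit leaves unreadable from compound 2 to compound 3.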

Compound 3, half-maximal inhibitory concentration: 1820 nM
Compound 3: the middle estimate sits 3.3-fold (0.52 log units) above what was measured; the measured number falls inside the stated range.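

In this assay, within the data shown here, the position ortho to a methoxy group now proves able to shift the read-out, which the earlier compounds could not show, as both stopped at a limit. Amino in place of nitro gives an at least 2.7-fold lower number from compound 2 to compound 3 (0.43 log units; beyond the scatter), and amino in place of hydrogen gives an at least 2.7-fold lower number from compound 1 to compound 3 (0.43 log units; beyond the scatter). Compound 3 is thus the first compound here with an exact number, while both steps give only a minimum size, and their full size stays hidden: the limit of > 5000 nM in this assay, at which 2 of the 3 values shown sit.

The compounds shown do not reveal what it is about the amino group that counts, and a hydroxyl group, a methylamino group or an acetamide at this same position would help to separate the possibilities. Going by these compounds, the step between hydrogen and nitro cannot be read, and it also stays open whether an amino group would give a similar step elsewhere on this ring or on the other side of the shared core.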